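The source may report more compounds than this note shows. Statements on the series, on what has been measured and on what is new or still open speak of the compounds shown alone.

Compound 1 `OC[C@H]1O[C@@H](n2cc(F)c3c(-c4cccs4)ncnc32)[C@H](O)[C@@H]1O` gives 9 nM in a functional assay on DU-145 cells (Homo sapiens), read by sulforhodamine B assay, with a stated time of 5 days; on this read-out lower numbers stand for stronger inhibition of growth and higher numbers for weaker inhibition of growth. Compound 2 `OC[C@H]1O[C@@H](n2cc(F)c3c(-c4ccoc4)ncnc32)[C@H](O)[C@@H]1O` gives 5 nM in this assay; it differs from compound 1 by furan-3-yl in place of thiophen-2-yl on an aromatic carbon, and the step was a 1.8-fold lower number from compound 1 to compound 2 (0.26 log units; within the scatter). Compound 3 `OC[C@H]1O[C@@H](n2cc(Cl)c3c(-c4cccs4)ncnc32)[C@H](O)[C@@H]1O` gives 13 nM in this assay; its core differs from the core of compound 1 by chloro in place of fluoro on an aromatic carbon, a step of a 1.4-fold higher number from compound 1 to compound 3 (0.16 log units; within the scatter). Compound 4 `OC[C@H]1O[C@@H](n2cc(Cl)c3c(-c4ccoc4)ncnc32)[C@H](O)[C@@H]1O` has not yet been measured in this assay. It differs from compound 3 by furan-3-yl in place of thiophen-2-yl on an aromatic carbon, the same change that was made from compound 1 to compound 2, at the same place. For compound 4 the expected step is a 1.9-fold lower number from compound 3 to compound 4 (0.27 log units; within the scatter). This expectation rests on the earlier instance of the change, because a 1.8-fold lower number from compound 1 to compound 2 (0.26 log units; within the scatter) stayed within the scatter. Compound 4 is therefore estimated at 7 nM, with an expected range from 3.5 nM to 14 nM.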

Compound 4, concentration for 50% growth inhibition: 54 nM
Beside the measured number, compound 4's estimate is 7.7-fold (0.89 log units) below it, and the stated range ends below it.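

In this assay, furan-3-yl in place of thiophen-2-yl on the chloro-bearing core gave a 4.2-fold higher number from compound 3 to compound 4 (0.62 log units; beyond the scatter), so the step seen on the fluoro-bearing core did not carry over: the same change on two cores in this assay, a 1.8-fold lower number (0.26 log units; within the scatter) from compound 1 to compound 2 and a 4.2-fold higher number (0.62 log units; beyond the scatter) from compound 3 to compound 4, 7.5-fold (0.87 log units) apart, beyond the scatter of two such steps. Read the other way, chloro in place of fluoro gave an 11-fold higher number from compound 2 to compound 4 (1.03 log units; beyond the scatter), so the size of this step also depends on the group on the aromatic carbon: the same change on two cores in this assay, a 1.4-fold higher number (0.16 log units; within the scatter) from compound 1 to compound 3 and an 11-fold higher number (1.03 log units; beyond the scatter) from compound 2 to compound 4, 7.5-fold (0.87 log units) apart, beyond the scatter of two such steps. The four compounds show that the two changes are not independent here, but they do not show why, and a single pair of cores cannot show how general this is.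

As far as these compounds go, it remains open whether thiophen-3-yl or furan-2-yl would show the same mismatch. The same holds for bromo or methyl in place of chloro.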